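Aryl sulfonamide variation on the shared core

This account rests on a few compounds, and the source may have more. Where it says the series, first, only, none or still open, it means among the compounds named here.

For the measured compounds named here, the three compounds measured so far share one core and differ only in the group on the sulfonyl sulfur. In a functional assay on HEK293 cells for agonist activity at probable G-protein coupled receptor 27 (Homo sapiens), read by a luciferase reporter and beta-arrestin recruitment, with a stated time of 10 min (on this read-out higher numbers stand for an effect only at larger amounts of compound and lower numbers for an effect already at smaller amounts), compound 1 `O=C(NS(=O)(=O)c1ccc(NC(=O)c2ccc(Cl)cc2Cl)cc1)c1ccccc1` gives > 100000 nM, which is a limit of the assay rather than a number. Compound 2 `CN(c1ccccc1)S(=O)(=O)c1ccc(NC(=O)c2ccc(Cl)cc2Cl)cc1` gives 2570 nM in this assay. Compound 3 `COc1ccc(NS(=O)(=O)c2ccc(NC(=O)c3ccc(Cl)cc3Cl)cc2)cc1` gives > 100000 nM, again a limit. Going by the values given here, compound 3 thus sits at the limit of > 100000 nM in this assay, at which 2 of the 3 values shown sit, together with compound 1, so that a step that the two limits leave unreadable from compound 1 to compound 3; the only readable step reaching it is an at least 38-fold higher number from compound 2 to compound 3 (1.59 log units; beyond the scatter), and the other large step, an at least 38-fold lower number from compound 1 to compound 2 (1.59 log units; beyond the scatter), also exchanges the whole group on the sulfur rather than a ring substituent. Compound 4 `O=C(Nc1ccc(S(=O)(=O)Nc2ccc(Cl)cc2)cc1)c1ccc(Cl)cc1Cl` differs from compound 3 by chloro in place of methoxy on an aromatic carbon. Among the compounds with values here, no measured step isolates such a substituent exchange on the aryl ring of the sulfonamide; both compounds with a hydrogen on the sulfonamide nitrogen sit at the limit. The expectation is therefore that compound 4 stays near the limit, a number no higher from compound 3 to compound 4 (the limit leaves the size open). Compound 4 is estimated at 100000 nM, within 10000 nM to 300000 nM.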

Compound 4, half-maximal effective concentration: > 100000 nM
Compound 4 gave a limit, no number; the forecaster's own chance of this, stated with the estimate: 70%; the middle value lies on the limit itself.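

Replacing methoxy with chloro on this aromatic carbon does not bring the compound off the limit in this assay: compound 4 gives > 100000 nM, which is a limit of the assay and not a number. The steps among compound 1, compound 3 and compound 4 cannot be read, but the (4-chlorophenyl)amino group now also stands well apart from the methyl(phenyl)amino group, with an at least 38-fold higher number from compound 2 to compound 4 (1.59 log units; beyond the scatter). A second substituent on this ring thus leaves compound 2, with its methyl on the sulfonamide nitrogen, as the only compound shown with a number rather than a limit: the limit of > 100000 nM in this assay, at which 3 of the 4 values shown sit.

Going by these compounds, it remains open whether that methyl alone separates compound 2 from compound 3 and compound 4, as each of these steps also changes the ring substituent. Also open, on these data alone, is how an ethyl group on that nitrogen, or a carboxylic acid or amine on the ring, would read.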